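The source may report more compounds than this note shows. Statements on the series, on what has been measured and on what is new or still open speak of the compounds shown alone.

Three compounds have been measured in a functional assay on corpus cavernosum (Rattus norvegicus) for activation; on this read-out lower numbers stand for smaller maximal responses and higher numbers for larger maximal responses:

compound 1 `O=c1[nH]c(-c2ccccc2O)nc2c1cnn2-c1ccc(Br)cc1` gives 167%
compound 2 `Nc1ccccc1NCc1nc2c(cnn2-c2ccccc2)c(=O)[nH]1` gives 113%
compound 3 `O=c1[nH]c(CNc2ccccc2O)nc2c1cnn2-c1ccccc1` gives 125%

Compound 2 stands lowest of these three. Its nearest neighbour is compound 3, reached by hydroxy in place of amino on an aromatic carbon, a change that moved the read-out by a number 12 percentage points higher from compound 2 to compound 3 (beyond the scatter), a modest gain beyond the usual scatter. Compound 1 lies well above both, but it differs from compound 2 in more than one place, so its value alone cannot be tied to any single change.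

Compound 4 `Nc1ccccc1NCc1nc2c(cnn2-c2ccc(Br)cc2)c(=O)[nH]1` is the next compound to be measured in this assay. It differs from compound 2 by bromo in place of hydrogen on an aromatic carbon. Within the data shown here, no measured step isolates this change: the only step known, from compound 2 to compound 3, concerns a different group at a different place. Compound 1 carries the same 4-bromophenyl and gives the largest response seen, yet its other differences from compound 2 prevent reading that as the effect of the bromo alone. The expectation is therefore a small shift, if any, slightly upward, amounting to a number 7 percentage points higher from compound 2 to compound 4 (within the scatter). For compound 4 the estimate is 120%, with a range from 95% to 150%.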

Compound 4, largest response reached (Emax), in percent of the reference or control that the assay uses: 148%
The estimate for compound 4 lay 28 percentage points below the measured number; the range from low to high includes it.
By their numbers in this assay, from the lowest: compound 2; then compound 3; then compound 4; then compound 1.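

Placing bromo on the phenyl ring, on an aromatic carbon para to a large group, raises the largest response in this assay by a clear margin: the change is a number 35 percentage points higher from compound 2 to compound 4 (beyond the scatter) and counts as large. Among these compounds, the only earlier single-place step, a number 12 percentage points higher from compound 2 to compound 3 (beyond the scatter) and counted as modest, concerned a different group at a different place, so this is the first direct reading of the phenyl to 4-bromophenyl change. It also adds context to compound 1, which carries the same 4-bromophenyl, since a single-place step now shows that this group can go with a higher response on at least one compound of the series. Nothing available explains what lies behind the rise.

This single pair cannot show whether the gain belongs to bromo itself or whether chloro, methyl or methoxy at the same place would give a similar response. It also leaves open whether the same change would raise the response of compound 3, which carries hydroxy in place of amino.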